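A Trifluoromethyl Isomer Awaits Its Solubility Reading

This account rests on a few compounds, and the source may have more. Where it says the series, first, only, none or still open, it means among the compounds named here.

Two related compounds have been measured so far. In a physicochemical assay for solubility, read by HPLC (a higher number here means a more soluble compound, a lower number a less soluble compound), compound 1 `O=C1NCc2ncc(-c3ccc(-c4cncc(NS(=O)(=O)c5ccc(F)cc5F)c4)s3)cc21` gives 3770 ug/mL, and compound 2 `CN1Cc2cc(-c3ccc(-c4cncc(NS(=O)(=O)c5cccc(C(F)(F)F)c5)c4)s3)cnc2C1=O` gives 20300 ug/mL. Compound 2 therefore holds the higher of the two numbers, and the gap between them lies beyond the usual scatter. The two compounds differ in more than one place, so this gap cannot be assigned to any single group.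

Compound 3 `CN1Cc2cc(-c3ccc(-c4cncc(NS(=O)(=O)c5ccccc5C(F)(F)F)c4)s3)cnc2C1=O` departs from compound 2 in one place: 2-(trifluoromethyl)phenyl in place of 3-(trifluoromethyl)phenyl on a sulfonyl sulfur. It carries 2-(trifluoromethyl)phenyl in place of 3-(trifluoromethyl)phenyl on a sulfonyl sulfur, so the two have the same atoms, joined differently. Within the data shown here, no measured pair yet shows what a single change does in this assay, so the expectation starts from compound 2 and its 20300 ug/mL. No shift beyond the scatter is expected, and the estimated step is a 1.4-fold lower number from compound 2 to compound 3 (0.13 log units; within the scatter). The estimate for compound 3 is 15000 ug/mL, with an expected range of 5000 ug/mL to 40000 ug/mL.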

Compound 3, solubility: 4280 ug/mL
Beside the measured number, compound 3's estimate is 3.5-fold (0.54 log units) above it; the whole stated range lies above it.
By their numbers in this assay, from the lowest: compounds 1 and 3 (each within the scatter of the next); then compound 2.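

Among these compounds, compound 2 and compound 3 form the first pair that shows what a single change does in this assay: 2-(trifluoromethyl)phenyl in place of 3-(trifluoromethyl)phenyl on a sulfonyl sulfur gives a 4.7-fold lower number from compound 2 to compound 3 (0.68 log units; beyond the scatter). Since the two compounds have the same atoms, joined differently, and the two groups match in every count given for them, this pair shows that the number at this position depends on how the trifluoromethyl group is joined to the phenyl ring, and not only on which atoms are present. No measurement at hand accounts for the size of this step.

This one pair leaves open whether the same change would give a step of similar size on another sulfonyl group, or on the core of compound 1, which differs from that of compound 2 and compound 3. It also leaves open what this position would give with an amine or a carboxylic acid on the phenyl ring in place of the trifluoromethyl group.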